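The source may hold more compounds than are shown below. What is called first, only, known or untested is meant among the compounds shown, and "the series" means these compounds.

Notes on the series. Compound 1 `CCC1(CCCCN2CCN(c3cccc(Cl)c3)CC2)C(=O)Nc2ccccc21` carries a 3-chlorophenyl group on the amine nitrogen in a ring of the shared core; in an assay on CHO cells for displacement of a labelled ligand from 5-hydroxytryptamine receptor 7 (Homo sapiens) (a lower number here means a stronger inhibitor, a higher number a weaker inhibitor), compound 1 gives 0.41 nM. Compound 2 `CCC1(CCCCN2CCN(c3ccccc3Cl)CC2)C(=O)Nc2ccccc21` carries 2-chlorophenyl instead, and in this assay compound 2 gives 5.11 nM; the step of a 12-fold higher number from compound 1 to compound 2 (1.10 log units; beyond the scatter) is beyond the scatter. Compound 3 `CCC1(CCCCN2CCN(c3ccc(Cl)c(Cl)c3)CC2)C(=O)Nc2ccccc21` carries 3,4-dichlorophenyl, and in this assay compound 3 gives 0.63 nM, the second highest of the three numbers; the step of a 1.5-fold higher number from compound 1 to compound 3 (0.19 log units; within the scatter) stays within the scatter, while the step of an 8.1-fold lower number from compound 2 to compound 3 (0.91 log units; beyond the scatter) lies beyond it.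

Compound 4 `CCC1(CCCCN2CCN(c3ccc(F)c(Cl)c3)CC2)C(=O)Nc2ccccc21` has not been measured. Its difference from compound 3 is fluoro in place of chloro on an aromatic carbon. The measured step that bears on this most directly is the one at the same place, a 1.5-fold higher number from compound 1 to compound 3 (0.19 log units; within the scatter), where chloro in place of hydrogen moved the number only within the scatter. The steps of a 12-fold higher number from compound 1 to compound 2 (1.10 log units; beyond the scatter) and an 8.1-fold lower number from compound 2 to compound 3 (0.91 log units; beyond the scatter) concern where the chloro sits on the aryl ring, not what occupies this carbon, so they offer little guidance. A fluoro at this carbon is therefore expected to shift this assay by no more than the scatter, in no set direction. The expected step is a 1.3-fold lower number from compound 3 to compound 4 (0.10 log units; within the scatter). For compound 4 the estimate is 0.5 nM, with a range from 0.2 nM to 1.5 nM.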

Compound 4, inhibition constant: 0.6 nM
Beside the measured number, compound 4's estimate is 1.2-fold (0.08 log units) below it; the range from low to high includes it.
By their numbers in this assay, from the lowest: compounds 1, 4 and 3 (each within the scatter of the next); then compound 2.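

Within the data shown here, at the aromatic carbon para to a large group, the exchange of chloro for fluoro gives a 1.1-fold lower number from compound 3 to compound 4 (0.02 log units; within the scatter) in this assay, and fluoro in place of hydrogen gives a 1.5-fold higher number from compound 1 to compound 4 (0.17 log units; within the scatter), so hydrogen, chloro and fluoro at this carbon now all lie within the scatter of one another; until now, only the pair of hydrogen and chloro had been compared here. The large gap to the 2-chlorophenyl compound also persists with the new substituent, as an 8.5-fold lower number from compound 2 to compound 4 (0.93 log units; beyond the scatter) shows, so the 3-chloro-4-fluorophenyl group stands apart from 2-chlorophenyl in the same way as the 3,4-dichlorophenyl group does. No measurement on hand explains why these halogen changes at this carbon leave the number within the scatter.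

Going by these compounds, all three groups compared at this carbon are hydrogen or a single halogen, so it remains open whether a methoxy, a trifluoromethyl, an amine or a carboxylic acid there would also stay within the scatter. On these data alone, it also remains open whether fluoro would behave the same way on the 2-chlorophenyl compound, where the number starts from a different level.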